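Chain swap on the ring nitrogen: compound 3 to compound 4

The source may report more compounds than this note shows. Statements on the series, on what has been measured and on what is new or still open speak of the compounds shown alone.

Three amides on the shared core are measured. Compound 1 `CCCC(N)C(=O)N1CCC(CN2CCC(NC(=O)c3cc(Cl)c(N)cc3OC)CC2)CC1` gives 2.57 nM in an assay on striatum for inhibition of 5-hydroxytryptamine receptor 4 (Cavia porcellus), read by radioligand binding; on this read-out higher numbers stand for weaker inhibition and lower numbers for stronger inhibition; compound 2 `COc1cc(N)c(Cl)cc1C(=O)NC1CCN(CC2CCN(C(=O)CCCN)CC2)CC1` gives 3.99 nM; compound 3 `COc1cc(N)c(Cl)cc1C(=O)NC1CCN(CC2CCN(C(=O)CCCCN)CC2)CC1` gives 3.91 nM. Compound 3 stands second highest of the three numbers, with compound 2 nearest at a 1.0-fold lower number from compound 2 to compound 3 (0.01 log units; within the scatter) and compound 1 furthest at a 1.5-fold higher number from compound 1 to compound 3 (0.18 log units; within the scatter), so all three sit within the scatter of one another.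

Compound 4 `COc1cc(N)c(Cl)cc1C(=O)NC1CCN(CC2CCN(CCCNS(C)(=O)=O)CC2)CC1` differs from compound 3 in one place: 3-(methanesulfonamido)propyl in place of (4-aminobutyl)carbonyl on an amine nitrogen in a ring. The steps measured so far all move the amino chain on the carbonyl carbon: a 1.6-fold higher number from compound 1 to compound 2 (0.19 log units; within the scatter), a 1.5-fold higher number from compound 1 to compound 3 (0.18 log units; within the scatter) and a 1.0-fold lower number from compound 2 to compound 3 (0.01 log units; within the scatter), none beyond the scatter. None of them removes the carbonyl or caps the amine, so the change to compound 4 is only partly covered. Given the flat response to chain changes seen in compound 1, compound 2 and compound 3, the step from compound 3 to compound 4 is expected to be small, a 1.3-fold higher number from compound 3 to compound 4 (0.11 log units; within the scatter), with a slight lean toward a higher number allowed for the uncovered part. Compound 4 is estimated at 5 nM, in the range 2 nM to 15 nM.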

Compound 4, half-maximal inhibitory concentration: 21.1 nM
The estimate for compound 4 lay 4.2-fold (0.63 log units) below the measured number; measured number outside the range, above it.
By their numbers in this assay, from the lowest: compounds 1, 3 and 2 (each within the scatter of the next); then compound 4.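

In this assay, for the compounds shown here, the steps of a 5.4-fold higher number from compound 3 to compound 4 (0.73 log units; beyond the scatter) and a 5.3-fold higher number from compound 2 to compound 4 (0.72 log units; beyond the scatter) and an 8.2-fold higher number from compound 1 to compound 4 (0.91 log units; beyond the scatter) are the first beyond the scatter, all at the amine nitrogen in the ring. The amino chain on the carbonyl carbon moves within the scatter across compound 1, compound 2 and compound 3, but this position does not absorb the swap to 3-(methanesulfonamido)propyl without a weaker read-out, although the leaving and entering groups carry the same counts of hydrogen-bond donors and acceptors. Nothing measured here accounts for the shift.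

The swap removes the carbonyl and caps the amine in a single step, so the compounds shown do not separate the two changes. A plain 3-aminopropyl chain on the same nitrogen, or a methanesulfonamido-capped chain still joined through the carbonyl, would each carry only one of them.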